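Replacing the benzimidazolyl group of compound 2

This account rests on a few compounds, and the source may have more. Where it says the series, first, only, none or still open, it means among the compounds named here.

Measured in a functional assay on PC-3 cells (Homo sapiens) for antiproliferative activity, read by CCK-8 assay, with a stated time of 6 days; on this read-out higher numbers stand for weaker inhibition and lower numbers for stronger inhibition:
Compound 1 `CCN(c1cccc(-c2ccccc2)c1)c1ccc(C#N)c(Cl)c1`: "not determined" (no result reported)
Compound 2 `CCN(c1ccc(C#N)c(Cl)c1)c1cc(-n2cnc3ccccc32)ccc1C`: 8160 nM
Compound 3 `CCN(c1cccc(-n2ccnc2)c1)c1ccc(C#N)c(C(F)(F)F)c1`: > 30000 nM (a limit of the assay, not a number)

Going by the values given here, compound 2 carries the only actual number in this small set, 8160 nM. Compound 3 is reported only as a limit, > 30000 nM. Compound 1 has no result to compare.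

The account now turns to compound 4 `CCN(c1ccc(C#N)c(Cl)c1)c1cc(-c2ccc(F)nc2)ccc1C`, which has not yet been measured. The structural change from compound 2 is 6-fluoropyridin-3-yl in place of 1H-benzimidazol-1-yl on an aromatic carbon. In short, 6-fluoropyridin-3-yl stands in place of 1H-benzimidazol-1-yl on an aromatic carbon.

Among the compounds with values here, no step between measured compounds is available to show how large such a change might be. The value of compound 2, 8160 nM, is therefore the only anchor, and no shift beyond the usual scatter is expected in this assay, in either direction. The expected size of the change is a 1.2-fold lower number from compound 2 to compound 4 (0.07 log units; within the scatter). For compound 4 the estimate is 7000 nM, with an expected range from 1800 nM to 28000 nM.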

Compound 4, half-maximal inhibitory concentration: > 30000 nM
Compound 4: only a limit was reported; the forecaster's own chance of this, stated with the estimate: 20%; middle value at least 4.2-fold (0.63 log units) away from the limit.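

Placing 6-fluoropyridin-3-yl in place of 1H-benzimidazol-1-yl on this aromatic carbon, para to a methyl group, gives an at least 3.6-fold higher number from compound 2 to compound 4 (0.56 log units; beyond the scatter) in this assay and so provides the first direct evidence that inhibition depends on the group held at this position. For compound 4, the entry > 30000 nM is a limit of the assay and not a number. On these data alone, the true size of the step stays unknown because the read-out stops at a ceiling: the limit of > 30000 nM in this assay, at which 2 of the 4 values shown sit.

The compounds shown leave open whether the fluorine or the pyridine ring accounts for the weaker inhibition, as a plain pyridin-3-yl or a 6-methoxypyridin-3-yl group would be needed to separate the two. They also leave open how a carboxylic acid or an amine on this carbon would compare with the 1H-benzimidazol-1-yl group of compound 2.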